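This account rests on a few compounds, and the source may have more. Where it says the series, first, only, none or still open, it means among the compounds named here.

In a functional assay on Hep cells (Homo sapiens) for cytotoxicity, read by sulforhodamine B assay, with a stated time of 48 h (on this read-out higher numbers stand for weaker inhibition and lower numbers for stronger inhibition), compound 1 `C=CCOc1ccc(F)cc1C(=O)c1cccnc1` gives > 100000 nM, which is a limit of the assay and not a number. For the measured compounds named here, compound 2 `C=CCOc1ccc(Br)cc1C(=O)c1cccnc1` gives 78000 nM, the only number so far. Compound 3 `C=CCOc1ccc(C)cc1C(=O)c1cccnc1` differs from compound 2 by methyl in place of bromo on an aromatic carbon, with methyl in place of bromo on an aromatic carbon para to an allyloxy group. Going by the values given here, the one measured step bearing on this is an at least 1.2-fold lower number from compound 1 to compound 2 (0.10 log units; that floor lies within the scatter), a change on the same aromatic carbon. Nothing beyond the scatter is therefore expected, and the expected step is a 1.1-fold higher number from compound 2 to compound 3 (0.04 log units; within the scatter). Compound 3 is estimated at 85000 nM, with an expected range of 45000 nM to 140000 nM.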

Compound 3, half-maximal inhibitory concentration: 72000 nM
Compound 3: middle estimate off by 1.2-fold (0.07 log units), on the high side, within the range that was stated.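

In this assay, methyl in place of bromo on the aromatic carbon para to the allyloxy group gives a 1.1-fold lower number from compound 2 to compound 3 (0.03 log units; within the scatter), so this position does not tell these two groups apart. Methyl in place of fluoro gives an at least 1.3-fold lower number from compound 1 to compound 3 (0.14 log units; that floor lies within the scatter), and that step is only a floor, so how far compound 1 lies from compound 3 stays unknown: the limit of > 100000 nM in this assay, at which 1 of the 3 values shown sits.

Still open, going by these compounds, is whether an amine or a carboxylic acid on this aromatic carbon would shift the number beyond the scatter. Also open, on these data alone, is whether a longer chain in place of the allyloxy group would do so.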